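A Fluoro for Propyl Swap on an Aromatic Carbon

The compounds below may be only part of what the source reports. "The series", "measured", "known", "first", "only" and "open" are said of these compounds alone.

In a functional assay (microsomes, liver) with Rattus norvegicus as the target (on this read-out lower numbers stand for stronger inhibition and higher numbers for weaker inhibition), three compounds have been measured so far. Compound 3 (`CCCc1ccc(C2c3c(C)c(N)c(C)c(C)c3OC2(C)C)cc1`) gives 290 nM and stands level with compound 1 (`CC(C)=Cc1c(C)c(N)c(C)c2c1OC(C)(C)C2`), which gives 300 nM in the same read-out, so the two lie within the scatter of each other. Compound 2 (`Cc1c(C)c2c(c(C)c1N)CC(C)(CN1CCN(c3ccccc3)CC1)O2`) gives 70 nM and lies lower than compound 3 by more than the scatter.

Compound 4 (`Cc1c(C)c2c(c(C)c1N)C(c1ccc(F)cc1)C(C)(C)O2`) has not yet been measured. It carries fluoro in place of propyl on an aromatic carbon, para to a large group (fluoro in place of propyl on an aromatic carbon). Among the measured compounds shown here, no two measured compounds differ in one place only, so the data offer no direct guide to this change. The closest hint is that compound 1 at 300 nM and compound 3 at 290 nM match despite their differing structures. On that limited basis, no step beyond the scatter is expected in this assay in either direction. The estimated change is a 1.1-fold lower number from compound 3 to compound 4 (0.05 log units; within the scatter) and would fall within the scatter. Compound 4 is expected at 260 nM with a range running from 100 nM to 650 nM in this estimate.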

Compound 4, half-maximal inhibitory concentration: 280 nM
Beside the measured number, compound 4's estimate is 1.1-fold (0.03 log units) below it; the range from low to high includes it.
By their numbers in this assay, from the lowest: compound 2; then compounds 4, 3 and 1 (each within the scatter of the next).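

In this assay, among the compounds shown here, putting fluoro in place of propyl on an aromatic carbon, para to a large group, gives a 1.0-fold lower number from compound 3 to compound 4 (0.02 log units; within the scatter), and this is the first pair that differs in one place only. The earlier compounds shown here differed in several places at once and could say nothing about a single exchange, whereas this pair shows that, at this position, propyl with its 3 heavy atoms and fluoro with its 1 can stand in for each other without a step beyond the scatter. Nothing available here accounts for the two groups reading alike.

What the compounds shown leave open is whether that tolerance extends to groups of another kind on the same aromatic carbon, such as an amine or a carboxylic acid, or to a longer chain such as hexyl. They also leave open whether the same exchange of fluoro for propyl would read alike on another core, such as the core of compound 2.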